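Working notes: acyl change on the amide of compound 3

The source may report more compounds than this note shows. Statements on the series, on what has been measured and on what is new or still open speak of the compounds shown alone.

Measured so far:
- compound 1 `OCCNc1nnc2nncn2n1`: 3310 nM
- compound 2 `OCC(CO)(CO)Nc1nnc2nncn2n1`: 12400 nM
- compound 3 `CCCCCC(=O)N1CCN(c2nnc3nncn3n2)CC1`: 2960 nM

In a functional assay on BeWo cells (Homo sapiens) for inhibition, read by MTT assay, with a stated time of 72 h (on this read-out lower numbers stand for stronger inhibition and higher numbers for weaker inhibition), compound 1 gives 3310 nM and compound 2 gives 12400 nM, while compound 3 gives 2960 nM. Compound 3 carries the lowest number of the three; compound 1 sits next to it within the scatter, so no order between the two can be read, and only compound 2 stands clearly apart, beyond the scatter. Within the data shown here, the three compounds share a core and differ in what hangs on it, but no pair differs in a single place, so no step between measured compounds is available.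

Compound 4 `O=C(C1CCCCC1)N1CCN(c2nnc3nncn3n2)CC1` is not yet measured. It differs from compound 3 by cyclohexyl in place of pentyl on a carbonyl carbon. Among the measured compounds shown here, nothing among the measured compounds mirrors this change, so its size can only be guessed. The step from compound 3 to compound 4 in this assay is expected to be a 1.1-fold lower number from compound 3 to compound 4 (0.04 log units; within the scatter), that is, no change beyond the scatter in either direction. Compound 4 is accordingly estimated at 2700 nM, with a range from 1000 nM to 7500 nM.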

Compound 4, half-maximal inhibitory concentration: 1900 nM
Compound 4: the middle estimate sits 1.4-fold (0.15 log units) above what was measured, and the stated range covers the measured number.
By their numbers in this assay, from the lowest: compounds 4, 3 and 1 (each within the scatter of the next); then compound 2.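

In this assay the series now has its first step in a single place, and a 1.6-fold lower number from compound 3 to compound 4 (0.19 log units; within the scatter) lies within the scatter, so cyclohexyl in place of pentyl on a carbonyl carbon gives no readable change. The earlier compounds shown here could not show this, as no pair among them differed in one place; for this pair, a six-membered ring of carbon only stands in for an open chain with no move beyond the scatter. No measured evidence bears on this result.

Still open, as far as these compounds go, is whether any group on this carbonyl carbon moves the number beyond the scatter, for instance phenyl, a chain longer than pentyl, or a chain ending in an amine or a carboxylic acid. From the compounds shown here alone, a single step within the scatter gives no trend for this place, and the same change on other members remains untested.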